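Acid to Ethylamide: Expected Cytotoxicity of Compound 4

A few compounds are considered here, and "the series" means these few. Any claim that something is new, unique, unknown or untested is made for them only; others in the source may bear on it.

Measured compounds:
compound 1, `OB1OCc2ccc(-n3cc(Sc4cccc(Cl)c4)c4ccccc43)cc21`: > 10 ug/mL
compound 2, `OB1OCc2ccc(-n3cccc3Sc3ccc(Cl)cc3)cc21`: > 10 ug/mL
compound 3, `O=C(O)c1cccn1-c1ccc2c(c1)B(O)OC2`: > 10 ug/mL

In an ADME assay on L929 cells (Mus musculus) for cytotoxicity, read by resazurin assay, with a stated time of 72 h (on this read-out higher numbers stand for weaker inhibition and lower numbers for stronger inhibition), compound 1 reaches only a limit of the assay, > 10 ug/mL, not a number. Compound 2 likewise stops at the limit > 10 ug/mL. Compound 3 also sits at the limit > 10 ug/mL. So compound 3 stands at the limit of > 10 ug/mL in this assay, at which 3 of the 3 values shown sit, together with the other two, and the numbers shown do not separate any of them.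

Compound 4, `CCNC(=O)c1cccn1-c1ccc2c(c1)B(O)OC2`, differs from compound 3 by ethylamino in place of hydroxy on a carbonyl carbon. Going by the values given here, no measured pair shows this change. The step from compound 3 to compound 4 a step that the limit leaves unreadable from compound 3 to compound 4 is expected to stay within the scatter, in no particular direction. Compound 4 is therefore estimated at 20 ug/mL, with a range from 7 ug/mL to 60 ug/mL.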

Compound 4, half-maximal inhibitory concentration: > 10 ug/mL
Compound 4: only a limit was reported (the forecaster's own chance of this, stated with the estimate: 75%); the middle value is on the limit's open side.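

Compound 3 and compound 4 both stop at a limit rather than a number, so no step between them can be read: the limit of > 10 ug/mL in this assay, at which 4 of the 4 values shown sit.

Whether ethylamino in place of hydroxy on the carbonyl carbon changes cytotoxicity at all, and where the true values of these compounds lie, stays open.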